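Compound 3 Loses Its Tert-Butyl Group

The compounds below may be only part of what the source reports. "The series", "measured", "known", "first", "only" and "open" are said of these compounds alone.

Measured in a functional assay on MCF7 cells (Homo sapiens) for inhibition, read by MTT assay, with a stated time of 72 h; on this read-out lower numbers stand for stronger inhibition and higher numbers for weaker inhibition:
- compound 1 `COc1ccc(-c2nnc(SCCCN3CCN(c4nc5ccccc5o4)CC3)o2)cc1`: 52800 nM
- compound 2 `Clc1ccc(-c2nnc(SCCCN3CCN(c4nc5ccccc5o4)CC3)o2)cc1`: 99700 nM
- compound 3 `CC(C)(C)Oc1ccc(-c2nnc(SCCCN3CCN(c4nc5ccccc5o4)CC3)o2)cc1`: 94900 nM

In this assay compound 3 gives 94900 nM, which cannot be told apart from the other two values. Its nearest neighbour is reached by a 1.1-fold lower number from compound 2 to compound 3 (0.02 log units; within the scatter), and its furthest by a 1.8-fold higher number from compound 1 to compound 3 (0.25 log units; within the scatter).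

The next compound is compound 4 `Oc1ccc(-c2nnc(SCCCN3CCN(c4nc5ccccc5o4)CC3)o2)cc1`, which has hydrogen in place of tert-butyl on an oxygen on an aromatic ring, taking tert-butoxy to hydroxy (hydrogen in place of tert-butyl on an oxygen on an aromatic ring).

Among the measured compounds shown here, the closest precedent changes the same oxygen: a 1.8-fold higher number from compound 1 to compound 3 (0.25 log units; within the scatter), with tert-butyl in place of methyl. The swaps involving chloro, a 1.9-fold higher number from compound 1 to compound 2 (0.28 log units; within the scatter) and a 1.1-fold lower number from compound 2 to compound 3 (0.02 log units; within the scatter), also stay within the scatter. For the measured compounds named here, no measured compound carries hydroxy, so this change itself has not been tested, and the three values offer only a narrow base for judging it.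

With no measured step beyond the scatter, no clear shift is expected in this assay. The expected step is a 1.4-fold lower number from compound 3 to compound 4 (0.13 log units; within the scatter), which is estimated to stay within the scatter. For compound 4 the estimated value is 70000 nM, with an expected range from 30000 nM to 150000 nM.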

Compound 4, half-maximal inhibitory concentration: 260000 nM
Estimate against measurement, compound 4: 3.7-fold (0.57 log units) below; measured number above the stated range.
By their numbers in this assay, from the lowest: compounds 1, 3 and 2 (each within the scatter of the next); then compound 4.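

In this assay, among the compounds shown here, the oxygen on the aromatic ring had carried methyl or tert-butyl with no step beyond the scatter, and hydrogen on that oxygen gives the first change here that goes beyond it, both from tert-butyl (a 2.7-fold higher number from compound 3 to compound 4 (0.44 log units; beyond the scatter)) and from methyl (a 4.9-fold higher number from compound 1 to compound 4 (0.69 log units; beyond the scatter)). The comparison with chloro on the same aromatic carbon points the same way (a 2.6-fold higher number from compound 2 to compound 4 (0.42 log units; beyond the scatter)), so among these four compounds hydroxy stands apart from methoxy, tert-butoxy and chloro, which could not be separated from one another, and it goes with weaker inhibition on this read-out. Nothing available bears on why the hydroxy compound behaves differently from the other three.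

The compounds shown leave open whether this step belongs to hydroxy alone or would also appear with an amine or a carboxylic acid on the same aromatic carbon. They also leave open whether the step would hold with a longer chain in place of the one shared by all four compounds, or on a different core.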